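Thiophen-3-yl in place of 4-methoxyphenyl on the shared core

The source may hold more compounds than are shown below. What is called first, only, known or untested is meant among the compounds shown, and "the series" means these compounds.

Measured so far:
compound 1 `CS(=O)(=O)c1ccc(-c2nc3ccccn3c2Sc2ccccc2)cc1` — 61900 nM
compound 2 `COc1ccc(-c2nc3ccccn3c2Sc2ccccc2)cc1` — 83900 nM

In a functional assay on SK-MEL-28 cells (Homo sapiens) for inhibition, read by MTT assay, with a stated time of 48 h (a higher number here means a weaker inhibitor, a lower number a stronger inhibitor), compound 2 stands at the higher of the two numbers, with compound 1 as its nearest neighbour after a 1.4-fold higher number from compound 1 to compound 2 (0.13 log units; within the scatter). Compound 3 `c1ccc(Sc2c(-c3ccsc3)nc3ccccn23)cc1` differs from compound 2 by thiophen-3-yl in place of 4-methoxyphenyl on an aromatic carbon. Among the compounds with values here, the only measured step, a 1.4-fold higher number from compound 1 to compound 2 (0.13 log units; within the scatter), alters a substituent on the 4-methoxyphenyl and stayed within the scatter; no step yet replaces that whole group. The expectation for compound 3 is therefore a step of a 1.2-fold lower number from compound 2 to compound 3 (0.08 log units; within the scatter), not beyond the scatter, in this assay. For compound 3 the estimated value is 70000 nM, with a range from 25000 nM to 200000 nM.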

Compound 3, half-maximal inhibitory concentration: 69300 nM
For compound 3 the middle estimate is 1.0-fold (0.00 log units) above the measured one; the range from low to high includes it.
By their numbers in this assay, from the lowest: compounds 1, 3 and 2 (each within the scatter of the next).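

Within the data shown here, replacing the whole 4-methoxyphenyl with thiophen-3-yl, on the aromatic carbon next to the ring atom bearing the phenylsulfanyl group, gives a 1.2-fold lower number from compound 2 to compound 3 (0.08 log units; within the scatter) in this assay and is the first change of the entire ring here. A five-membered aromatic ring with 5 heavy atoms thus stands in for a six-membered one with 8 without a step beyond the scatter. No available evidence bears on the reason for this result.

From the compounds shown here alone, whether an aminomethyl group or a carboxylic acid on this carbon would give a step beyond the scatter remains open. So does the effect of any replacement of the phenylsulfanyl group.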